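Furan-2-yl ketone variant of the aryl ketone series

The source may hold more compounds than are shown below. What is called first, only, known or untested is meant among the compounds shown, and "the series" means these compounds.

Within the data shown here, compound 3 `COc1cc(-c2nnc3n2NC(c2ccco2)C(C(=O)c2ccc(-c4ccccc4)cc2)S3)cc(OC)c1OC` gives 45900 nM in a functional assay on PC-3 cells (Homo sapiens) for cytotoxicity, read by MTT assay, with a stated time of 48 h (a higher number here means a weaker inhibitor, a lower number a stronger inhibitor), which places it second highest of the three numbers measured so far. Compound 1 `COc1cc(-c2nnc3n2NC(c2ccco2)C(C(=O)C2CC2)S3)cc(OC)c1OC` gives 95200 nM in this assay, and compound 2 `COc1cc(-c2nnc3n2NC(c2ccco2)C(C(=O)c2ccc(C)cc2)S3)cc(OC)c1OC` gives 7500 nM. The measured steps show a 13-fold lower number from compound 1 to compound 2 (1.10 log units; beyond the scatter), a 2.1-fold lower number from compound 1 to compound 3 (0.32 log units; beyond the scatter) and a 6.1-fold higher number from compound 2 to compound 3 (0.79 log units; beyond the scatter).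

Compound 4 `COc1cc(-c2nnc3n2NC(c2ccco2)C(C(=O)c2ccco2)S3)cc(OC)c1OC` has not been measured. It differs from compound 3 by furan-2-yl in place of 4-phenylphenyl on a carbonyl carbon. The change on the carbonyl carbon is the same site varied in the measured steps, so all three bear on it, though none exchanges a 4-phenylphenyl for a five-membered aromatic ring with one hetero atom. The smaller aryl group in compound 2 gave the lowest number, and the step from compound 2 to compound 3 was the modest rise already cited, so a return to a smaller aromatic ketone is expected to lower the number, by less than the methyl-to-phenyl step given the unrelated ring type.

Compound 4 is therefore expected to give about 15000 nM in this assay, within 4000 nM to 60000 nM, an estimated step of a 3.1-fold lower number from compound 3 to compound 4 (0.49 log units; beyond the scatter).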

Compound 4, half-maximal inhibitory concentration: 58300 nM
Beside the measured number, compound 4's estimate is 3.9-fold (0.59 log units) below it; measured number inside the range.
By their numbers in this assay, from the lowest: compound 2; then compounds 3, 4 and 1 (each within the scatter of the next, the first and the last beyond it).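

In this assay, furan-2-yl (5 heavy atoms) in place of 4-phenylphenyl (12 heavy atoms) on the carbonyl carbon gives a 1.3-fold higher number from compound 3 to compound 4 (0.10 log units; within the scatter), so across this pair the heavy-atom count of the group does not separate the two numbers. Furan-2-yl does stand apart from 4-methylphenyl, with a 7.8-fold higher number from compound 2 to compound 4 (0.89 log units; beyond the scatter), but not from cyclopropyl, with a 1.6-fold lower number from compound 1 to compound 4 (0.21 log units; within the scatter), which leaves compound 2 as the only one of the four whose steps to all the others lie beyond the scatter. No measured evidence is at hand to account for this single separation at the carbonyl carbon.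

The compounds shown leave open whether the low number of compound 2 depends on the methyl group itself, a question that plain phenyl, 4-methoxyphenyl or 4-chlorophenyl on the carbonyl carbon would address. They also leave open whether a five-membered aromatic ring can reach that level at all, for which thiophen-2-yl or a methyl-bearing furan-2-yl would be the closest comparisons.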